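Compound 3 to compound 4: a 5-(methoxymethyl)furan-2-yl swap

The compounds below may be only part of what the source reports. "The series", "measured", "known", "first", "only" and "open" are said of these compounds alone.

Measured in a functional assay on HT-29 cells (Homo sapiens) for cytotoxicity, read by MTT assay, with a stated time of 72 h; a higher number here means a weaker inhibitor, a lower number a stronger inhibitor
- compound 1 `O=c1[nH]/c(=C\c2nc[nH]c2C2CC2)c(=O)[nH]/c1=C\c1cccc(Oc2ccc(F)cc2)c1` gives 7.4 nM
- compound 2 `O=C(c1ccc(F)cc1)c1cccc(/C=c2\[nH]c(=O)/c(=C/c3nc[nH]c3C3CC3)[nH]c2=O)c1` gives 1.4 nM
- compound 3 `O=C(c1ccc(F)cc1)c1cccc(/C=c2\[nH]c(=O)/c(=C/c3c[nH]cn3)[nH]c2=O)c1` gives 5.1 nM

Of these three numbers, compound 3 has the second highest. It lies within the scatter of compound 1 and beyond the scatter from compound 2, which has the lowest number.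

Compound 4 `COCc1ccc(/C=c2\[nH]c(=O)/c(=C/c3cccc(C(=O)c4ccc(F)cc4)c3)[nH]c2=O)o1` differs from compound 3 by 5-(methoxymethyl)furan-2-yl in place of 1H-imidazol-4-yl on a double-bonded chain carbon bound to an aromatic carbon and is otherwise the same.

The closest measured evidence is a 3.6-fold higher number from compound 2 to compound 3 (0.56 log units; beyond the scatter) with hydrogen in place of cyclopropyl on an aromatic carbon of the imidazole group. The other measured step, a 5.3-fold lower number from compound 1 to compound 2 (0.72 log units; beyond the scatter) with (4-fluorophenyl)carbonyl in place of 4-fluorophenoxy, concerns a group that stays unchanged here and bears only indirectly. Both steps were modest, and neither exchanges the whole imidazole group, so the data give no direct measure of this swap.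

Taking a 3.6-fold higher number from compound 2 to compound 3 (0.56 log units; beyond the scatter) as a rough guide, a modest or somewhat larger rise in this assay is expected, with wide uncertainty. The expected step is a 4.3-fold higher number from compound 3 to compound 4 (0.63 log units; beyond the scatter) and it remains an estimate. Compound 4 is therefore estimated at 22 nM with a range from 6 nM to 90 nM as the expected span.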

Compound 4, half-maximal inhibitory concentration: 2.2 nM
For compound 4 the middle estimate is 10-fold (1.00 log units) above the measured one; measured number below the stated range.
By their numbers in this assay, from the lowest: compounds 2 and 4 (each within the scatter of the next); then compounds 3 and 1 (each within the scatter of the next).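

In this assay, going by these compounds alone, this position on a double-bonded chain carbon bound to an aromatic carbon proves to accept far more than the imidazoles of the earlier compounds suggested: exchanging 1H-imidazol-4-yl for the larger 5-(methoxymethyl)furan-2-yl, which has no hydrogen-bond donor, gives a 2.3-fold lower number from compound 3 to compound 4 (0.37 log units; beyond the scatter), a modest step beyond the scatter. Set against the 5-cyclopropyl-1H-imidazol-4-yl group, the same furan gives a 1.6-fold higher number from compound 2 to compound 4 (0.20 log units; within the scatter), which lies within the scatter, so an imidazole ring is not required at this position for a low nanomolar number in this series. Nothing measured here bears on what lies behind this result.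

The furan ring and its methoxymethyl chain enter in one step, so the compounds shown cannot divide the change between them, and a furan carrying a carboxylic acid or an amine at the same place would test how much that chain matters. As far as these compounds go, it also stays open whether this swap would give a similar step with the 4-fluorophenoxy group of compound 1 in place of the (4-fluorophenyl)carbonyl group.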